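This account rests on a few compounds, and the source may have more. Where it says the series, first, only, none or still open, it means among the compounds named here.

Measured in an ADME assay on MT4 cells (Homo sapiens) for cytotoxicity, with a stated time of 5 days (a higher number here means that more compound is tolerated, a lower number that less compound is tolerated), all three values being limits:
- compound 1 `CC(C)(C)C#Cc1cc(N(C(=O)[C@H]2CC[C@H](C)CC2)[C@H]2CC[C@H](OC3CCOCC3)CC2)c(C(=O)O)s1`: > 20000 nM
- compound 2 `CC(C)(C)C#Cc1cc(N(C(=O)[C@H]2CC[C@H](C)CC2)[C@H]2C[C@@H](Oc3cccnc3)C2)c(C(=O)O)s1`: > 20000 nM
- compound 3 `C[C@@H]1CC[C@@H](C(=O)N(c2cc(C#CC(C)(C)C)sc2C(=O)O)[C@H]2CC[C@H](OC3CCOC3)CC2)[C@@H](O)C1`: > 20000 nM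

Compound 2 gives > 20000 nM, which is a limit and not a number. None of the three compounds yields a number: the limit of > 20000 nM in this assay, at which 3 of the 3 values shown sit. Compound 4 `C[C@@H](CCOc1cccnc1)N(c1cc(C#CC(C)(C)C)sc1C(=O)O)C(=O)[C@H]1CC[C@H](C)CC1` differs from compound 2 on the amide-type nitrogen, with 1-methyl-3-((pyridin-3-yl)oxy)propyl in place of 3-((pyridin-3-yl)oxy)cyclobutyl on an amide-type nitrogen. Among the measured compounds shown here, no measured step in this set tests such a change. No shift beyond the scatter is expected, and the estimated step is a number no higher from compound 2 to compound 4 (the limit leaves the size open). Another limit is the most likely report. In this assay the estimate for compound 4 is 20000 nM, with the expected range running from 10000 nM to 40000 nM.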

Compound 4, half-maximal cytotoxic concentration: > 20000 nM
Compound 4: a limit, no number; the forecaster's own chance of this, stated with the estimate: 80%; the middle value lies on the limit itself.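

No step can be read from compound 2 to compound 4, as both results are limits and not numbers: the limit of > 20000 nM in this assay, at which 4 of the 4 values shown sit.

Whether the compounds shown differ in tolerated concentration at all remains open, as does how far each lies past that limit.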